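Distal aryl variation in the legumain nitrile series

This account rests on a few compounds, and the source may have more. Where it says the series, first, only, none or still open, it means among the compounds named here.

Three compounds share one core and differ only in the distal aromatic ring. Compound 1 `C[C@H](C(=O)N[C@H](C#N)CC(N)=O)N(Cc1ccc(-c2cc(F)cc(F)c2)cc1)S(C)(=O)=O` gives 9250 nM in an assay on isolated protein for inhibition of legumain (Homo sapiens), with stated times of 2 min and 60 min; a lower number here means a stronger inhibitor, a higher number a weaker inhibitor; compound 2 `C[C@H](C(=O)N[C@H](C#N)CC(N)=O)N(Cc1ccc(-c2ccc(F)c(F)c2)cc1)S(C)(=O)=O` gives 6300 nM, and compound 3 `CC(C)Oc1cccc(-c2ccc(CN([C@H](C)C(=O)N[C@H](C#N)CC(N)=O)S(C)(=O)=O)cc2)c1` gives 5050 nM. Compound 3 carries the lowest of the three numbers, yet its steps to compound 2 and compound 1 are a 1.2-fold lower number from compound 2 to compound 3 (0.10 log units; within the scatter) and a 1.8-fold lower number from compound 1 to compound 3 (0.26 log units; within the scatter), both within the scatter, as is a 1.5-fold lower number from compound 1 to compound 2 (0.17 log units; within the scatter). Compound 4 `C[C@H](C(=O)N[C@H](C#N)CC(N)=O)N(Cc1ccc(-c2ccc(F)cc2)cc1)S(C)(=O)=O` is the next member: 4-fluorophenyl in place of 3-isopropoxyphenyl on an aromatic carbon. All three measured steps change this same ring and none moves beyond the scatter, so no step beyond the scatter is expected from compound 3 to compound 4, that is a 1.4-fold higher number from compound 3 to compound 4 (0.14 log units; within the scatter). Compound 4 is therefore estimated at 7000 nM, with a range of 3500 nM to 14000 nM.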

Compound 4, half-maximal inhibitory concentration: > 10000 nM
Compound 4 was reported as a limit; the forecaster's own chance of this, stated with the estimate: 5%; middle value at least 1.4-fold (0.15 log units) from the limit.
By their numbers in this assay, from the lowest: compounds 3, 2 and 1 (each within the scatter of the next). At a limit, above all of these: compound 4.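

Compound 4 in this assay is reported only as a limit: the limit of > 10000 nM in this assay, at which 1 of the 4 values shown sits.
The steps to it are floors only: an at least 1.9-fold higher number from compound 3 to compound 4 (0.29 log units; that floor lies within the scatter) and an at least 1.5-fold higher number from compound 2 to compound 4 (0.20 log units; that floor lies within the scatter) and an at least 1.0-fold higher number from compound 1 to compound 4 (0.03 log units; that floor lies within the scatter).
From the compounds shown here alone, with 4-fluorophenyl on this aromatic carbon, the series gives its first open-ended reading, but no floor shows a change beyond the scatter, and the true size of each step stays unknown.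
Still open, going by these compounds, is whether an amine or a carboxylic acid on the distal ring would give a value clear of the scatter. The same holds for an alkoxy chain longer than isopropoxy.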